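The compounds below may be only part of what the source reports. "The series", "measured", "known", "first", "only" and "open" are said of these compounds alone.

Compound 1 `Cc1ccccc1Cn1ccc2nc(-c3ccccc3)nc-2c1` gives in an ADME assay on MDBK cells (Bos taurus) for cytotoxicity (on this read-out higher numbers stand for lower toxicity in this test and lower numbers for higher toxicity in this test), the limit > 100000 nM.
Compound 2 `COc1ccccc1Cn1ccc2nc(-c3ccccc3)nc-2c1` gives in this assay the limit > 100000 nM.
Compound 3 `Clc1ccc(Cn2ccc3nc(-c4ccccc4)nc-3c2)cc1` gives in this assay the limit > 100000 nM.

Compound 1 stands only at a limit in this assay, and the two other values are limits as well, since (the limit of > 100000 nM in this assay, at which 3 of the 3 values shown sit). The steps a step that the two limits leave unreadable from compound 1 to compound 2, a step that the two limits leave unreadable from compound 1 to compound 3 and a step that the two limits leave unreadable from compound 2 to compound 3 therefore cannot be read in size. Compound 4 `Clc1ccc(Cn2ccc3nc(-c4ccccc4)nc-3c2)cc1Cl` differs from compound 1 by 3,4-dichlorophenyl in place of 2-methylphenyl on a saturated chain carbon bound to an aromatic nitrogen. The step from compound 1 to compound 3 is the closest comparison, but it too is unreadable. With nothing pointing away from the limit, compound 4 is expected to sit at 150000 nM, between 50000 nM and 500000 nM, a step that the limit leaves unreadable from compound 1 to compound 4 that is expected to stay within the scatter.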

Compound 4, half-maximal cytotoxic concentration: 71000 nM
The estimate for compound 4 lay 2.1-fold (0.32 log units) above the measured number, within the range that was stated.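

In this assay, for the compounds shown here, compound 4 is the first compound carrying its group on a saturated chain carbon bound to an aromatic nitrogen to give a number rather than a limit. The change now reads as an at least 1.4-fold lower number from compound 1 to compound 4 (0.14 log units; that floor lies within the scatter), as an at least 1.4-fold lower number from compound 3 to compound 4 (0.14 log units; that floor lies within the scatter) and as an at least 1.4-fold lower number from compound 2 to compound 4 (0.14 log units; that floor lies within the scatter). Only these floors can be stated and the earlier steps remain unreadable, because the other compounds stand at a limit: the limit of > 100000 nM in this assay, at which 3 of the 4 values shown sit.

From the compounds shown here alone, it remains open whether the true gap between 3,4-dichlorophenyl and the other groups exceeds the scatter. Going by these compounds, how an amine or a carboxylic acid in place of chloro would read also remains open.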